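Ethoxy in place of the aryl ether on the quinone-type core

This account rests on a few compounds, and the source may have more. Where it says the series, first, only, none or still open, it means among the compounds named here.

Compound 1 `COCCOc1cc2ncnc(NC3=CC(=O)C(SC)=CC3=O)c2cc1OC`: 2 h
Compound 2 `COCCOc1cc2ncnc(NC3=CC(=O)C(Oc4ccc(-n5ccnc5)cc4)=CC3=O)c2cc1OC`: < 0.02 h

Both values come from an ADME assay for pharmacokinetics, tested at 1 uM, in the presence of a further agent that is not named here; on this read-out higher numbers stand for a longer-lived compound and lower numbers for a shorter-lived compound. For compound 2, < 0.02 h is a limit and not a number.

Compound 3 `CCOC1=CC(=O)C(Nc2ncnc3cc(OCCOC)c(OC)cc23)=CC1=O` has ethyl in place of 4-(1H-imidazol-1-yl)phenyl on an oxygen on an unsaturated carbon.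

Among the compounds with values here, the one measured step at this place is an at least 100-fold lower number from compound 1 to compound 2 (2.00 log units; beyond the scatter), a large step that introduced the 4-(1H-imidazol-1-yl)phenoxy group. Losing that aryl group is therefore expected to give a large rise in this assay, towards compound 1 with 2 h. The expected change is an at least 50-fold higher number from compound 2 to compound 3 (1.69 log units; beyond the scatter). For compound 3 the estimate is 1 h, with an expected range of 0.15 h to 6 h.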

Compound 3, half-life: 62 h
Compound 3: middle estimate off by 62-fold (1.79 log units), on the low side, outside the stated range (above it).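

In this assay ethoxy does more than restore the methylsulfanyl level: a 31-fold higher number from compound 1 to compound 3 (1.49 log units; beyond the scatter) comes with that swap, so this place can carry the half-life well past that of compound 1. Ethoxy in place of 4-(1H-imidazol-1-yl)phenoxy gives an at least 3100-fold higher number from compound 2 to compound 3 (3.49 log units; beyond the scatter) on the shared core. That size is only a bound, because compound 2 stands at a limit and not a number: the limit of < 0.02 h in this assay, at which 1 of the 3 values shown sits.

Going by these compounds, whether an amine or a longer chain such as propoxy on this carbon would keep the gain stays open. Also open, on these data alone, is whether the half-life follows the oxygen link or the ethyl group itself.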